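The source may hold more compounds than are shown below. What is called first, only, known or untested is meant among the compounds shown, and "the series" means these compounds.

Compound 2, `O=C1NC(=O)/C(=C/c2cn(Cc3ccccc3)c3ccc(Br)cc23)N1`, is the reference point here. Among the compounds with values here, in a functional assay on MDA-MB-231 cells (Homo sapiens) for antiproliferative activity, read by trypan blue exclusion, with a stated time of 24 h (on this read-out higher numbers stand for weaker inhibition and lower numbers for stronger inhibition), compound 2 gives 12400 nM, the lowest of the two numbers measured so far. Within the data shown here, its only neighbour is compound 1, `O=C1NC(=O)/C(=C/c2cn(Cc3ccccc3)c3ccc(Cl)cc23)N1`, which in this assay gives 18000 nM; the step of a 1.5-fold lower number from compound 1 to compound 2 (0.16 log units; within the scatter) is within the scatter, so the two compounds cannot be ranked against each other.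

Compound 3, `COc1ccc2c(c1)c(/C=C1\NC(=O)NC1=O)cn2Cc1ccccc1`, is the next compound to be measured in this assay. It differs from compound 2 by one change: methoxy in place of bromo on an aromatic carbon. Among the measured compounds shown here, only one measured step bears on this change, and only loosely: the step of a 1.5-fold lower number from compound 1 to compound 2 (0.16 log units; within the scatter) exchanged one halogen for another at the same aromatic carbon and stayed within the scatter. For the measured compounds named here, no measured step replaces a halogen with a methoxy group, so the data give no direct guide to the direction of the change.

The expectation for compound 3 is therefore a step within the scatter, a 1.2-fold higher number from compound 2 to compound 3 (0.08 log units; within the scatter), with no claimed direction. The estimate for compound 3 in this assay is 15000 nM, with a range from 6000 nM to 40000 nM.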

Compound 3, half-maximal inhibitory concentration: 7000 nM
For compound 3 the middle estimate is 2.1-fold (0.33 log units) above the measured one; the measured number falls inside the stated range.
By their numbers in this assay, from the lowest: compounds 3, 2 and 1 (each within the scatter of the next, the first and the last beyond it).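

Within the data shown here, at this aromatic carbon, methoxy is the first group that is not a halogen. In this assay, among these compounds, its exchange for bromo gives a 1.8-fold lower number from compound 2 to compound 3 (0.25 log units; within the scatter), so compound 2 and compound 3 cannot be ranked against each other, while its exchange for chloro gives a 2.6-fold lower number from compound 1 to compound 3 (0.41 log units; beyond the scatter), a modest step and the only one among the three compounds that lies beyond the scatter. The position therefore accepts a group with one more heavy atom than bromo and a hydrogen-bond acceptor that bromo lacks, with no loss of antiproliferative activity on this read-out, although no information at hand accounts for the modest difference from the chloro compound.

The compounds shown leave open whether the oxygen link matters, since a hydroxyl, an amine or a plain methyl group on the same carbon would separate it from the size of the group, and a longer chain such as ethoxy would show how much more room the position accepts. They also leave open whether the same order of groups would hold if the shared core were changed elsewhere.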